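The compounds below may be only part of what the source reports. "The series", "measured", "known", "first", "only" and "open" are said of these compounds alone.

Of the compounds shown here, two have so far been tested in a functional assay on PC-3 cells (Homo sapiens) for inhibition, read by MTT assay, with a stated time of 72 h; on this read-out higher numbers stand for weaker inhibition and lower numbers for stronger inhibition. Within the data shown here, compound 1, with the structure `Fc1ccccc1Cn1cc(CSC(=S)N2CCNCC2)nn1`, gives 56200 nM in this assay, and that is the only number obtained so far. Compound 2, with the structure `CC(C)(C)OC(=O)N1CCN(C(=S)SCc2cn(Cc3ccc(Cl)cc3)nn2)CC1`, returns only a limit of the assay in this assay, namely > 128000 nM. The limit of > 128000 nM in this assay, at which 1 of the 2 values shown sits, is therefore where one of the two results sits, so compound 1 stands as the sole measured point against which a new compound can be weighed.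

The next compound, compound 3 with the structure `COc1ccc(Cn2cc(CSC(=S)N3CCNCC3)nn2)cc1`, keeps the shared core of compound 1 and differs in one place: 4-methoxyphenyl in place of 2-fluorophenyl on a saturated chain carbon bound to an aromatic nitrogen. Among the measured compounds shown here, no measured pair in this set follows the same kind of change, so the size of the step rests on expectation alone. Both aromatic groups are small and the rest of the molecule is unchanged, so compound 3 is expected to land close to compound 1, with a step of a 1.1-fold higher number from compound 1 to compound 3 (0.03 log units; within the scatter) that does not exceed the usual scatter. Compound 3 is thus estimated at 60000 nM in this assay, within a range from 25000 nM to 130000 nM.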

Compound 3, half-maximal inhibitory concentration: > 128000 nM
Compound 3 gave a limit, no number (the forecaster's own chance of this, stated with the estimate: 25%); middle value at least 2.1-fold (0.32 log units) from the limit.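

Among these compounds, changing the aromatic group on a saturated chain carbon bound to an aromatic nitrogen gives the first single-place comparison in this assay, and putting 4-methoxyphenyl in place of 2-fluorophenyl produces an at least 2.2-fold higher number from compound 1 to compound 3 (0.35 log units; beyond the scatter). A higher number stands for weaker inhibition here, so inhibition is weaker with 4-methoxyphenyl, which shows that this position is sensitive to the choice between these two aromatic groups. Compound 3 gives a limit of the assay rather than a number, so the true size of the step remains unknown, and the series now has little measured range to compare against: the limit of > 128000 nM in this assay, at which 2 of the 3 values shown sit.

The pair cannot show whether the step comes from losing 2-fluorophenyl or from gaining 4-methoxyphenyl, since both groups change at once; a plain phenyl, a 4-fluorophenyl or a 2-methoxyphenyl would help to separate the two. On these data alone, it also remains open whether any group at this position, such as a pyridyl ring or a longer chain ending in an amine, could give stronger inhibition than the 2-fluorophenyl of compound 1.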